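Glycinamide series: adding a side chain at the alpha carbon

The compounds below may be only part of what the source reports. "The series", "measured", "known", "first", "only" and "open" are said of these compounds alone.

Measured compounds and values in a functional assay on the whole organism (Tail, strain ICR) with Mus musculus as the target, in the tail flick test, with a stated time of 60 min, at a dose of 25 umol/kg by the oral route; a lower number here means a weaker effect, a higher number a stronger effect of the compound at the dose given:
- compound 1 `O=C(CN(c1ncnc2c1ncn2C1CCCCO1)C1CC1)NCC(=O)OCc1ccccc1`: 40.4%
- compound 2 `O=C(CN(c1nc(Cl)nc2[nH]cnc12)C1CC1)N[C@@H](CC(=O)OCc1ccccc1)C(=O)OCc1ccccc1`: 22.4%
- compound 3 `O=C(O)CNC(=O)CN(c1nc(Cl)nc2[nH]cnc12)C1CC1`: 38.9%

Compound 1 gives the highest of the three numbers in this assay. Compound 3 comes nearest, with a value that lies within the usual scatter of compound 1, so no order between these two can be read. Compound 2 is the furthest away, and its value lies beyond the scatter below compound 1; the two differ in more than one place, so this gap is not assigned to any single change.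

Compound 4 `CC(C)(C)OC(=O)NCCCC[C@H](NC(=O)CN(c1ncnc2c1ncn2C1CCCCO1)C1CC1)C(=O)OCc1ccccc1` is not yet measured. It differs from compound 1 as follows: 4-((tert-butoxycarbonyl)amino)butyl in place of hydrogen on a saturated chain carbon bound to an amide-type nitrogen and a carbonyl carbon. Going by the values given here, this is a large addition on a saturated chain carbon bound to an amide-type nitrogen and a carbonyl carbon, and there is no measured pair that isolates such a change.

Compound 2, which also carries a substituent on that carbon together with other changes, sits well below compound 1. On that basis, compound 4 is expected to come out lower than compound 1, with a step of a number 13.4 percentage points lower from compound 1 to compound 4 (beyond the scatter) that goes beyond the scatter. The estimate for compound 4 is 27%, with a range from 10% to 45%.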

Compound 4, a percentage reported as activity, at one dose (the size of the read-out at that dose, not a potency): 32.7%
Compound 4: middle estimate off by 5.7 percentage points, on the low side; the measured number falls inside the stated range.
By their numbers in this assay, from the lowest: compound 2; then compounds 4, 3 and 1 (each within the scatter of the next).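

In this assay, going by these compounds alone, 4-((tert-butoxycarbonyl)amino)butyl in place of hydrogen on the saturated chain carbon bound to an amide-type nitrogen and a carbonyl carbon gives a number 7.7 percentage points lower from compound 1 to compound 4 (within the scatter), the first step that isolates a substituent at this position. A large addition of 12 heavy atoms at this carbon therefore leaves the read-out at the dose given without a change that can be told from the scatter. Nothing available bears on why this is so.

As far as these compounds go, only one substituent at this carbon can be read so far, so a small alkyl group, a shorter chain, or a free amine or carboxylic acid at the chain end remains open. From the compounds shown here alone, whether the same holds in the opposite configuration at this carbon also remains open.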